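The source may report more compounds than this note shows. Statements on the series, on what has been measured and on what is new or still open speak of the compounds shown alone.

Measured compounds in a functional assay on the whole organism for inhibition, with Digitaria ciliaris as the target, with a stated time of 72 h, tested at 100 mg/L; a lower number here means less inhibition of growth, a higher number more inhibition of growth at the concentration tested:

Compound 1 `COc1cc(Cl)nc(NC(=S)NC(=O)c2c(-c3ccc(Cl)cc3Cl)noc2C)n1` gives 62.2%.
Compound 2 `COc1cc(C)nc(NC(=S)NC(=O)c2c(-c3ccc(Cl)cc3Cl)noc2C)n1` gives 60.2%.
Compound 3 `CSc1cc(C)nc(NC(=S)NC(=O)c2c(-c3ccc(Cl)cc3Cl)noc2C)n1` gives 45.5%.

Among these three, compound 3 stands lowest: compound 2 sits a number 14.7 percentage points lower from compound 2 to compound 3 (beyond the scatter) apart from it, and compound 1 sits a number 16.7 percentage points lower from compound 1 to compound 3 (beyond the scatter) apart from it, both gaps beyond the scatter. Compound 1 and compound 2 are not separated, as a number 2 percentage points lower from compound 1 to compound 2 (within the scatter) shows.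

Compound 4 `COc1cc(OC)nc(NC(=S)NC(=O)c2c(-c3ccc(Cl)cc3Cl)noc2C)n1` has not yet been measured. It differs from compound 3 in one place: 4,6-dimethoxypyrimidin-2-yl in place of 4-methyl-6-(methylsulfanyl)pyrimidin-2-yl on an amide-type nitrogen. Among the measured compounds shown here, two measured steps bear on this. The exchange of methylsulfanyl for methoxy, seen as a number 14.7 percentage points lower from compound 2 to compound 3 (beyond the scatter), is the step most closely related, and read in the reverse direction it points to a modest rise. For the measured compounds named here, the exchange of methyl for chloro, a number 2 percentage points lower from compound 1 to compound 2 (within the scatter), was within the scatter, while methyl for methoxy on that ring has no measured counterpart. Compound 4 is therefore expected to show a step of a number 14.5 percentage points higher from compound 3 to compound 4 (beyond the scatter) in this assay, upward. The estimate for compound 4 in this assay is 60%, ranging from 45% to 75%.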

Compound 4, percent growth inhibition at one concentration: 65.9%
The estimate for compound 4 lay 5.9 percentage points below the measured number, and the stated range covers the measured number.
By their numbers in this assay, from the lowest: compound 3; then compounds 2, 1 and 4 (each within the scatter of the next).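

In this assay, 4,6-dimethoxypyrimidin-2-yl in place of 4-methyl-6-(methylsulfanyl)pyrimidin-2-yl on the amide-type nitrogen gives a clear change (a number 20.4 percentage points higher from compound 3 to compound 4 (beyond the scatter)). A further methoxy on the aromatic carbon adds nothing that can be told apart, whether it replaces methyl (a number 5.7 percentage points higher from compound 2 to compound 4 (within the scatter)) or chloro (a number 3.7 percentage points higher from compound 1 to compound 4 (within the scatter)). Chloro, methyl and methoxy on that carbon are therefore not separated in compound 1, compound 2 and compound 4, which all carry methoxy, and the new result sets compound 3, with methylsulfanyl, further apart from this group.

No supporting measurement is available to explain these differences. Going by these compounds, it remains open whether an amine or an ethoxy group on that aromatic carbon would stay level with this group, and whether methylsulfanyl would lower the number with chloro or methoxy as its partner.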